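Ethoxy for iodo on a shared core

The compounds below may be only part of what the source reports. "The series", "measured", "known", "first", "only" and "open" are said of these compounds alone.

Compound 1 `O=C1C=C(Nc2ccc(Cl)cc2)C(=O)c2[nH]c(-c3ccccn3)nc21`: 13000 nM
Compound 2 `O=C1C=C(Nc2ccc(I)cc2)C(=O)c2[nH]c(-c3ccccn3)nc21`: 20000 nM

Of the compounds shown here, two on one core have been tested in an ADME assay (Rattus norvegicus) for inhibition; a lower number here means a stronger inhibitor, a higher number a weaker inhibitor. Compound 1 gives 13000 nM in this assay. Compound 2 gives 20000 nM. Among the measured compounds shown here, the only step between them, a 1.5-fold higher number from compound 1 to compound 2 (0.19 log units; within the scatter), lies within the scatter, so compound 2 stands level with compound 1 and neither can be called the stronger inhibitor.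

Compound 3 `CCOc1ccc(NC2=CC(=O)c3nc(-c4ccccn4)[nH]c3C2=O)cc1` is not yet measured. It differs from compound 2 by ethoxy in place of iodo on an aromatic carbon. For the measured compounds named here, no measured step involves an ethoxy group; the one step available, a halogen exchange at the same place, gave a 1.5-fold higher number from compound 1 to compound 2 (0.19 log units; within the scatter), which is within the scatter. On that basis no change beyond the scatter is expected for compound 3, and the expected step is a 1.2-fold lower number from compound 2 to compound 3 (0.07 log units; within the scatter). Compound 3 is therefore estimated at 17000 nM in this assay, with a range from 6000 nM to 50000 nM.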

Compound 3, half-maximal inhibitory concentration: 6500 nM
Beside the measured number, compound 3's estimate is 2.6-fold (0.42 log units) above it; the measured number falls inside the stated range.
By their numbers in this assay, from the lowest: compounds 3, 1 and 2 (each within the scatter of the next, the first and the last beyond it).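

The exchange of one halogen for another had left the number in this assay within the scatter, but ethoxy in place of iodo on the same aromatic carbon gives a step beyond it, a 3.1-fold lower number from compound 2 to compound 3 (0.49 log units; beyond the scatter), showing that this position can respond, modestly, to the group placed there. That response is seen only against iodo: against chloro the step is a 2.0-fold lower number from compound 1 to compound 3 (0.30 log units; within the scatter), which leaves compound 3 level with compound 1, so ethoxy cannot be called stronger than both halogens. Nothing available explains the step from iodo to ethoxy.

The compounds shown leave open whether this step is particular to ethoxy or would carry over to methoxy or a longer chain such as butoxy. They also leave open how an amine or a carboxylic acid on this aromatic carbon would compare.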